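The source may hold more compounds than are shown below. What is called first, only, known or untested is meant among the compounds shown, and "the series" means these compounds.

Measured in a functional assay on MCF7 cells (Homo sapiens) for cytotoxicity, read by MTT assay, with a stated time of 72 h, tested at 3 uM; a higher number here means more inhibition of growth at the concentration tested, a lower number less inhibition of growth:
- compound 1, `N/C(=N\NC(=S)N1CCSCC1)c1ccccn1`: 29%
- compound 2, `N/C(=N\NC(=S)N1CCCC1)c1ccccn1`: 49.8%

Among the compounds with values here, compound 1 stands lowest of the two numbers; the one step recorded, a number 20.8 percentage points higher from compound 1 to compound 2 (beyond the scatter), exchanges the ring on the thiocarbonyl carbon and leaves the aromatic six-membered ring with one nitrogen untouched.

Compound 3, `N/C(=N\NC(=S)N1CCSCC1)c1ccc(F)cn1`, differs from compound 1 only there: fluoro in place of hydrogen on an aromatic carbon, two atoms from the ring nitrogen. Within the data shown here, no measured step in this assay touches that ring, so the recorded step from compound 1 to compound 2 does not bear on this change and gives no direction for it. With nothing comparable to lean on, no step beyond the scatter is expected in this assay for compound 3, and the estimate is placed near the value of compound 1 with a wide range. Compound 3 is therefore expected to give 32% in this assay, between 14% and 52%, which means an expected step of a number 3 percentage points higher from compound 1 to compound 3 (within the scatter).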

Compound 3, percent growth inhibition at one concentration: 35.4%
Beside the measured number, compound 3's estimate is 3.4 percentage points below it; the range from low to high includes it.
By their numbers in this assay, from the lowest: compounds 1 and 3 (each within the scatter of the next); then compound 2.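

In this assay, within the data shown here, the first measured change on the aromatic six-membered ring with one nitrogen, fluoro in place of hydrogen two atoms from the ring nitrogen and para to a large group, gives a number 6.4 percentage points higher from compound 1 to compound 3 (within the scatter) and so does not separate the two compounds. This position therefore accepts a single fluorine on the core of compound 1 without a step beyond the scatter, whereas the ring on the thiocarbonyl carbon still carries the only such step shown. Nothing available gives a cause for this result.

As far as these compounds go, whether a larger group at this position, such as methoxy, an amine or a carboxylic acid, would move the growth inhibition beyond the scatter remains open. Also open, from the compounds shown here alone, is whether fluoro behaves the same way with pyrrolidin-1-yl on the thiocarbonyl carbon.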